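The source may hold more compounds than are shown below. What is called first, only, known or untested is meant among the compounds shown, and "the series" means these compounds.

Three analogues share a nitro-bearing sulfonamide core and have been measured in an assay on SK-BR-3 cells for inhibition of Aromatase (Homo sapiens); on this read-out lower numbers stand for stronger inhibition and higher numbers for weaker inhibition. Compound 1 `CS(=O)(=O)Nc1ccc([N+](=O)[O-])cc1OCc1ccc2ccccc2c1` gives 2170 nM. Compound 2 `CS(=O)(=O)Nc1ccc([N+](=O)[O-])cc1OCc1ccccc1-c1ccccc1` gives 260 nM. Compound 3 `COc1ccc(COc2cc([N+](=O)[O-])ccc2N(C)S(C)(=O)=O)cc1` gives 470 nM, which places it second highest of the three numbers; its nearest neighbour is compound 2, whose value lies within the scatter of repeated measurements, while compound 1 sits farthest away, beyond the scatter on the weaker side.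

Compound 4 `CN(c1ccc([N+](=O)[O-])cc1OCc1ccc(-c2ccccc2)cc1)S(C)(=O)=O` has not yet been measured in this assay. It differs from compound 3 in one place: phenyl in place of methoxy on an aromatic carbon. For the measured compounds named here, no step between measured compounds isolates this exchange, so the size of the change is open. Because compound 2 gives 260 nM with a phenyl-bearing benzyl group and compound 3 gives 470 nM, a step from compound 3 to compound 4 of a 1.0-fold lower number from compound 3 to compound 4 (0.02 log units; within the scatter) is expected, which would be none beyond the scatter. Compound 4 is therefore estimated at 450 nM, with a range from 130 nM to 1600 nM.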

Compound 4, half-maximal inhibitory concentration: 650 nM
Compound 4: the middle estimate sits 1.4-fold (0.16 log units) below what was measured; the range from low to high includes it.
By their numbers in this assay, from the lowest: compounds 2, 3 and 4 (each within the scatter of the next, the first and the last beyond it); then compound 1.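

In this assay, for the compounds shown here, phenyl in place of methoxy on an aromatic carbon, para to a large group, gives a 1.4-fold higher number from compound 3 to compound 4 (0.14 log units; within the scatter) and is the first step to isolate this position. The position therefore accepts a six-membered aromatic ring of six heavy atoms in place of a two-heavy-atom group that carries a hydrogen-bond acceptor, with the read-out staying within the scatter. Nothing available bears on why the two groups give numbers this close.

From the compounds shown here alone, whether this holds for other groups at the same place, such as an amine, a carboxylic acid or a longer alkyl chain, remains open. What the methyl group on the sulfonamide nitrogen contributes also stays open, since no single-place comparison among these compounds addresses it.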